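The source may report more compounds than this note shows. Statements on the series, on what has been measured and on what is new or still open speak of the compounds shown alone.

Among the measured compounds shown here, in an ADME assay on L929 cells (Mus musculus) for cytotoxicity, read by resazurin assay, with a stated time of 96 h (on this read-out lower numbers stand for higher toxicity in this test and higher numbers for lower toxicity in this test), compound 1 (`NC(=S)N/N=C(\COc1ccccc1)c1ccc(Br)cc1`) gives 54900 nM and stands highest of the three numbers so far. Compound 2 (`CC(C)c1ccc(OC/C(=N\NC(N)=S)c2ccc(Br)cc2)cc1`) gives 24600 nM and compound 3 (`CC(C)(C)c1ccc(OC/C(=N\NC(N)=S)c2ccc(Br)cc2)cc1`) gives 23800 nM and these two do not separate. The step under review leads to compound 4 (`COc1cccc(OC/C(=N\NC(N)=S)c2ccc(Br)cc2)c1`), with methoxy in place of hydrogen on an aromatic carbon, meta to a large group (methoxy in place of hydrogen on an aromatic carbon). For the measured compounds named here, two measured steps bear on it. Isopropyl in place of hydrogen on an aromatic carbon gives a 2.2-fold lower number from compound 1 to compound 2 (0.35 log units; beyond the scatter) and tert-butyl in the same kind of exchange gives a 2.3-fold lower number from compound 1 to compound 3 (0.36 log units; beyond the scatter) as a similar modest change, while a 1.0-fold lower number from compound 2 to compound 3 (0.01 log units; within the scatter) shows no separation between those two. Going by the values given here, no methoxy compound has been measured. Among the compounds with values here, with compound 2 at 24600 nM and compound 3 at 23800 nM as the only guides, a lower number is expected in this assay but with a shorter step than either. The expected step is a 1.7-fold lower number from compound 1 to compound 4 (0.22 log units; within the scatter) and it may not clear the scatter. Compound 4 is estimated at 33000 nM with 16000 nM to 65000 nM as the expected range.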

Compound 4, half-maximal cytotoxic concentration: 50700 nM
Estimate against measurement, compound 4: 1.5-fold (0.19 log units) below; low and high end bracket the measured number.
By their numbers in this assay, from the lowest: compounds 3 and 2 (each within the scatter of the next); then compounds 4 and 1 (each within the scatter of the next).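

In this assay, methoxy on an aromatic carbon, meta to a large group, gives a step that stays within the scatter: a 1.1-fold lower number from compound 1 to compound 4 (0.03 log units; within the scatter). Among the compounds shown here, it is the first substituent on this ring of the series to do so, set against a 2.2-fold lower number from compound 1 to compound 2 (0.35 log units; beyond the scatter) and a 2.3-fold lower number from compound 1 to compound 3 (0.36 log units; beyond the scatter), so a lower number does not follow from every group added to this ring. No measurement shown explains why these steps differ.

The compounds shown do not separate the effect of the group from the effect of its place on the ring, since methoxy is the only group shown meta to a large group. As far as these compounds go, how an amine, a hydroxyl group or a chlorine atom at this same place would read in this assay remains open.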